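The compounds below may be only part of what the source reports. "The series", "measured", "known", "first", "only" and "open" are said of these compounds alone.

The compounds measured so far:
compound 1 `O=C(Nc1ccc(Cl)c(-c2ccccn2)c1)c1ccccc1`, in an assay on C3H 10T1/2 cells for inhibition of Sonic hedgehog protein (Mus musculus), read by a luciferase reporter (on this read-out lower numbers stand for stronger inhibition and higher numbers for weaker inhibition), compound 1 gives 800 nM
compound 2 `O=C(Nc1ccc(Cl)c(-c2ccccn2)c1)c1cccc(Cl)c1`, in this assay compound 2 gives 1500 nM

Among the compounds with values here, compound 2 holds the higher of the two numbers, yet the only step connecting it to compound 1, a 1.9-fold higher number from compound 1 to compound 2 (0.27 log units; within the scatter), lies within the scatter, so the two compounds cannot be ordered against each other in this assay. Compound 3 `CS(=O)(=O)c1cccc(C(=O)Nc2ccc(Cl)c(-c3ccccn3)c2)c1` differs from compound 2 by methylsulfonyl in place of chloro on an aromatic carbon. Within the data shown here, no measured step exchanges one substituent for another at this position; the one known step, a 1.9-fold higher number from compound 1 to compound 2 (0.27 log units; within the scatter), concerns the chloro that now leaves, and it stayed within the scatter. On that ground a step of size no change at the digits printed from compound 2 to compound 3 (within the scatter) is expected in this assay, with no clear direction beyond the scatter. Compound 3 is therefore estimated at 1500 nM, with a range from 500 nM to 5000 nM.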

Compound 3, half-maximal inhibitory concentration: 120 nM
Beside the measured number, compound 3's estimate is 13-fold (1.10 log units) above it; the measured number lies below the stated range.
By their numbers in this assay, from the lowest: compound 3; then compounds 1 and 2 (each within the scatter of the next).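

Within the data shown here, the position is not indifferent to its substituent: in this assay, methylsulfonyl in place of chloro gives a 13-fold lower number from compound 2 to compound 3 (1.10 log units; beyond the scatter), the first step to lie beyond the scatter. Set against the hydrogen of compound 1, the same group gives a 6.7-fold lower number from compound 1 to compound 3 (0.82 log units; beyond the scatter), so compound 3 stands apart from both earlier compounds, whereas exchanging hydrogen for chloro had produced no readable change. The data at hand offer no explanation of why methylsulfonyl behaves so differently from chloro here.

The compounds shown contain only one sulfonyl-bearing group, so it remains open whether an ethylsulfonyl, a sulfonamide or a carboxylic acid on this aromatic carbon would give a similar number. From the compounds shown here alone, it is also open whether methylsulfonyl would give the same step at another carbon of this ring.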